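Ring-closed amine variant of the uracil series

The source may report more compounds than this note shows. Statements on the series, on what has been measured and on what is new or still open speak of the compounds shown alone.

Compound 3 `COc1cccc(-c2c(C)n(Cc3c(F)cccc3F)c(=O)n([C@@H](C)CNCc3ccccc3F)c2=O)c1` gives 550 nM in an assay on HEK293 cells for binding affinity to Gonadotropin-releasing hormone receptor (Homo sapiens) (on this read-out higher numbers stand for weaker inhibition and lower numbers for stronger inhibition), the second highest of the three numbers: compound 1 `COc1cccc(-c2c(C)n(Cc3c(F)cccc3F)c(=O)n([C@@H](C)CNCC(C)C)c2=O)c1` gives 1200 nM and compound 2 `COc1cccc(-c2c(C)n(Cc3c(F)cccc3F)c(=O)n([C@H](C)CNCc3ccccc3F)c2=O)c1` gives 90 nM. The steps measured so far are a 2.2-fold lower number from compound 1 to compound 3 (0.34 log units; beyond the scatter) and a 6.1-fold higher number from compound 2 to compound 3 (0.79 log units; beyond the scatter), the latter resting on (the fact that compounds 2 and 3 differ only in the configuration as drawn); the large step of a 13-fold lower number from compound 1 to compound 2 (1.12 log units; beyond the scatter) combines both changes. Compound 4 `COc1cccc(-c2c(C)n(Cc3c(F)cccc3F)c(=O)n(C3CCN(Cc4ccccc4)C3)c2=O)c1` carries 1-benzylpyrrolidin-3-yl in place of 1-(((2-fluorobenzyl)amino)methyl)ethyl on an aromatic nitrogen, a change in which the defined stereocentre is lost and the hydrogen-bond donor count falls from one to none. Within the data shown here, no measured step covers closing the chain into a ring, and the stereochemical step shows the series is sensitive near this position. A modest change in either direction is expected, so the estimated step is a 1.4-fold lower number from compound 3 to compound 4 (0.14 log units; within the scatter). Compound 4 is therefore estimated at 400 nM, within 100 nM to 1600 nM.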

Compound 4, inhibition constant: 280 nM
Compound 4: middle estimate off by 1.4-fold (0.15 log units), on the high side, within the range that was stated.
By their numbers in this assay, from the lowest: compound 2; then compounds 4 and 3 (each within the scatter of the next); then compound 1.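

The 1-benzylpyrrolidin-3-yl group is accepted on this aromatic nitrogen without the chain's hydrogen-bond donor or a defined stereocentre, giving a 2.0-fold lower number from compound 3 to compound 4 (0.29 log units; within the scatter). The ring form still falls short of the R-drawn open chain, with a 3.1-fold higher number from compound 2 to compound 4 (0.49 log units; beyond the scatter), while it improves on the isobutylamino chain, with a 4.3-fold lower number from compound 1 to compound 4 (0.63 log units; beyond the scatter). Nothing in the data at hand accounts for these steps.

Open, on these data alone, is whether a 1-(2-fluorobenzyl)pyrrolidin-3-yl or a piperidin-3-yl group would narrow the gap to compound 2. Also open, as far as these compounds go, is whether the two configurations of the pyrrolidine ring carbon separate as compounds 2 and 3 do.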